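A few compounds are considered here, and "the series" means these few. Any claim that something is new, unique, unknown or untested is made for them only; others in the source may bear on it.

Measured so far:
compound 1, `CC[S+]([O-])(=NC)c1ccc(Nc2ncc(C(F)(F)F)c(N[C@@H]3CCC[C@H]3N(C)C)n2)cc1`: in an ADME assay on microsomes from liver (Homo sapiens) (a higher number here means that the liver removes a larger share of the compound in one pass, a lower number that the liver removes a smaller share), compound 1 gives 0.58
compound 2, `CCN=[S+](C)([O-])c1ccc(Nc2ncc(C(F)(F)F)c(N[C@@H]3CCC[C@H]3N(C)C)n2)cc1`: in this assay compound 2 gives 0.54; 0.58; 0.64 (3 entries)

Compound 1 holds the only single number shown; the repeated entries of compound 2 sit within the usual scatter of it, so the two show no difference worth naming (the several entries of compound 2 in this assay, 0.54; 0.58; 0.64 (3 entries)). Compound 3 is `CN(C)[C@@H]1CCC[C@H]1Nc1nc(Nc2ccc([S+](C)(=N)[O-])cc2)ncc1C(F)(F)F` and awaits measurement. Against compound 1 it differs in one place: a group of 4 heavy atoms (1 carbon, 1 nitrogen, 1 oxygen, 1 sulfur; no ring) in place of a group of 6 heavy atoms (3 carbon, 1 nitrogen, 1 oxygen, 1 sulfur; no ring), on an aromatic carbon. Going by the values given here, no step between measured compounds bears on a change of this kind, so its size is open; a modest move downward, possibly not beyond the scatter, is expected. Compound 3 is estimated at 0.5, within 0.35 to 0.65. The expected step is a number 0.080 lower from compound 1 to compound 3 (within the scatter).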

Compound 3, hepatic extraction ratio: < 0.29
Compound 3: a limit, no number (the forecaster's own chance of this, stated with the estimate: 0%); at least 0.21 between middle value and limit.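

In this assay compound 3 gives < 0.29, a limit of the assay and not a number. Replacing the group of 6 heavy atoms with the group of 4 heavy atoms on this aromatic carbon gives a number at least 0.29 lower from compound 1 to compound 3 (beyond the scatter), so the read-out responds to this position in a way that compound 1 and compound 2 did not show. The full size of the step cannot be read: the limit of < 0.29 in this assay, at which 1 of the 3 values shown sits.

The compounds shown do not separate the loss of heavy atoms from the gain of a hydrogen-bond donor. On these data alone, how a sulfone or a primary sulfonamide on the same aromatic carbon would read in this assay stays open.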